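The source may hold more compounds than are shown below. What is called first, only, known or untested is meant among the compounds shown, and "the series" means these compounds.

Compound 1, `O=C(Nc1ccc(Cl)c(Cl)c1)c1nc[nH]c1C(=O)NCc1ccc(Cl)cc1`: 16200 nM
Compound 2, `COc1ccc(CNC(=O)c2[nH]cnc2C(=O)Nc2ccc(Cl)c(Cl)c2)cc1`: 24300 nM
Compound 3, `COC(=O)[C@H](NC(=O)c1[nH]cnc1C(=O)Nc1ccc(Cl)c(Cl)c1)c1ccccc1`: 17300 nM

All three were tested in a functional assay on HL-60 cells (Homo sapiens), with a stated time of 2 days; on this read-out lower numbers stand for stronger inhibition and higher numbers for weaker inhibition. Compound 1 has the lowest of the three numbers, but both other numbers lie within the usual scatter of it: the step of a 1.5-fold higher number from compound 1 to compound 2 (0.18 log units; within the scatter) stays within the scatter, and compound 3 gives 17300 nM, also within the scatter of compound 1.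

Compound 4, `COC(=O)[C@H](NC(=O)c1[nH]cnc1C(=O)Nc1ccc(Cl)c(Cl)c1)C(C)C`, differs from compound 1 in this way: 1-(methoxycarbonyl)-2-methylpropyl in place of 4-chlorobenzyl on an amide-type nitrogen. For the measured compounds named here, no measured step covers this change; the only measured step concerns a different position and was itself within the scatter. A step beyond the scatter is therefore not expected, and the change is estimated as a 1.1-fold higher number from compound 1 to compound 4 (0.05 log units; within the scatter). For compound 4 the expected value is 18000 nM, with a range from 8000 nM to 40000 nM.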

Compound 4, half-maximal inhibitory concentration: 8500 nM
Estimate against measurement, compound 4: 2.1-fold (0.33 log units) above; the range from low to high includes it.
By their numbers in this assay, from the lowest: compounds 4, 1, 3 and 2 (each within the scatter of the next, the first and the last beyond it).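

Putting the ring-free 1-(methoxycarbonyl)-2-methylpropyl in place of 4-chlorobenzyl on the amide-type nitrogen gives a 1.9-fold lower number from compound 1 to compound 4 (0.28 log units; within the scatter) and so shows that, among these compounds, this position holds its level of inhibition without an aromatic ring. Isopropyl in place of phenyl gives a 2.0-fold lower number from compound 3 to compound 4 (0.31 log units; beyond the scatter) and the same group in place of 4-methoxybenzyl gives a 2.9-fold lower number from compound 2 to compound 4 (0.46 log units; beyond the scatter) with both of these modest steps favouring compound 4. Nothing available explains these differences.

Still open, on these data alone, is whether a carboxylic acid in place of the methyl ester would keep this level of inhibition. As far as these compounds go, an amine on this chain, or a longer chain in place of isopropyl, also remains untested here.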